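Adding a Methyl Group: From Compound 2 Toward Compound 3

The source may report more compounds than this note shows. Statements on the series, on what has been measured and on what is new or still open speak of the compounds shown alone.

Measured so far:
compound 1, `Cc1ccnc(/C(N)=N/NC(=S)N2CCOCC2)c1`, gives 8.16% in a functional assay on MCF7 cells (Homo sapiens) for cytotoxicity, read by MTT assay, with a stated time of 72 h, tested at 30 uM; on this read-out lower numbers stand for less inhibition of growth and higher numbers for more inhibition of growth at the one concentration tested.
compound 2, `N/C(=N\NC(=S)N1CCCC1)c1ccccn1`, gives 54.6% in this assay.

On these two numbers compound 2 stands highest; compound 1 lies far lower, a gap beyond the scatter. Compound 3, `Cc1ccnc(/C(N)=N/NC(=S)N2CCCC2)c1`, differs from compound 2 by methyl in place of hydrogen on an aromatic carbon, a methyl in place of hydrogen on an aromatic carbon. Among the compounds with values here, no measured pair isolates this change, since compound 1 carries the methyl but also a different ring on the thiourea. Still, the low value of compound 1 8.16% hints that methyl-bearing analogues may sit lower. Compound 3 is therefore expected to lose some inhibition, a step of a number 19.6 percentage points lower from compound 2 to compound 3 (beyond the scatter) of moderate size. The estimate for compound 3 is 35%, within 10% to 60%.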

Compound 3, percent growth inhibition at one concentration: 82.2%
For compound 3 the middle estimate is 47.2 percentage points below the measured one; measured number above the stated range.
By their numbers in this assay, from the lowest: compound 1; then compound 2; then compound 3.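

In this assay, methyl in place of hydrogen on the aromatic carbon opposite the ring nitrogen raises the value (a number 27.6 percentage points higher from compound 2 to compound 3 (beyond the scatter)), so a methyl here goes with more inhibition of growth, at least alongside pyrrolidin-1-yl. With the methyl kept, pyrrolidin-1-yl in place of morpholin-4-yl gives a much larger step (a number 74 percentage points higher from compound 1 to compound 3 (beyond the scatter)), so the low value of compound 1 goes with its morpholin-4-yl ring rather than its methyl. Nothing here explains either step.

From the compounds shown here alone, whether an ethyl group or an amine at this position would do the same remains open, as does the effect of the methyl alongside morpholin-4-yl.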